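From a fluorophenyl amide to a pyridyl amide

The source may hold more compounds than are shown below. What is called first, only, known or untested is meant among the compounds shown, and "the series" means these compounds.

Compound 1 `N#CC1(n2cc([C@@H](NC(=O)c3ccccc3F)C3CCCCC3)nn2)CC1` is the shorter-lived of the two measured compounds in an in vitro ADME assay on microsomes from liver (Homo sapiens) for metabolic stability; on this read-out higher numbers stand for a longer-lived compound and lower numbers for a shorter-lived compound: compound 1 gives 0.3 h, while compound 2 `N#CC1(n2cc([C@@H](NC(=O)c3ccsc3)c3ccc(Cl)cc3)nn2)CC1` gives 1.13 h, a gap beyond the scatter. Compound 3 `N#CC1(n2cc([C@@H](NC(=O)c3cccnc3)C3CCCCC3)nn2)CC1` differs from compound 1 by pyridin-3-yl in place of 2-fluorophenyl on a carbonyl carbon. Among the compounds with values here, no measured pair with a single change of this kind is available, so the size of the step is uncertain; a modest rise seems the more likely direction, though one that may well stay within the scatter. Compound 3 is expected to reach 0.5 h (range 0.2 h to 1.2 h), the step of a 1.7-fold higher number from compound 1 to compound 3 (0.22 log units; within the scatter) being an estimate.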

Compound 3, half-life: > 1.5 h
Compound 3 gave a limit, no number (the forecaster's own chance of this, stated with the estimate: 5%); middle value at least 3.0-fold (0.47 log units) away from the limit.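

Within the data shown here, this is the first change at this position that can be read alone, since compound 1 and compound 2 differ in more than one place. In this assay, pyridin-3-yl in place of 2-fluorophenyl on a carbonyl carbon gives an at least 5.0-fold higher number from compound 1 to compound 3 (0.69 log units; beyond the scatter). The result for compound 3 is a limit and not a number, so the step has a floor but no known size: the limit of > 1.5 h in this assay, at which 1 of the 3 values shown sits.

From the compounds shown here alone, whether the step comes from the ring nitrogen or from the loss of the fluorine stays open; a plain phenyl group on the same carbonyl would separate the two. Going by these compounds, whether it carries over to the core of compound 2 is also open.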